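This account rests on a few compounds, and the source may have more. Where it says the series, first, only, none or still open, it means among the compounds named here.

Measured compounds:
compound 1, `Cc1nc2c3ccccc3ccc2c2nc3c(ccc4ccccc43)c(-c3cccnc3)c12`, 3860 nM
compound 2, `Cc1nc2c3ccccc3ccc2c2nc3c(ccc4ccccc43)c(-c3cccc4ccccc34)c12`, 14900 nM

Both values come from a functional assay on HeLa cells (Homo sapiens) for cytotoxicity, read by MTT assay, with a stated time of 48 h; a higher number here means a weaker inhibitor, a lower number a stronger inhibitor. Compound 2 gives the highest of the two numbers; its nearest neighbour is compound 1, which lies a 3.9-fold higher number from compound 1 to compound 2 (0.59 log units; beyond the scatter).

Compound 3 is `Cc1nc2c3ccccc3ccc2c2nc3c(ccc4ccccc43)c(-c3ccc(O)cc3)c12`, unmeasured. It differs from compound 2 by 4-hydroxyphenyl in place of naphthalen-1-yl on an aromatic carbon.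

Going by the values given here, only one measured step bears on this change. Going from compound 1 to compound 2 replaced pyridin-3-yl with naphthalen-1-yl and gave a 3.9-fold higher number from compound 1 to compound 2 (0.59 log units; beyond the scatter). The move from compound 2 to compound 3 reverses that direction, exchanging naphthalen-1-yl for a single six-membered ring that carries a hydrogen-bond donor and acceptor. A step downward in this assay of roughly similar size is therefore expected for compound 3, about a 3.3-fold lower number from compound 2 to compound 3 (0.52 log units; beyond the scatter). Compound 3 is estimated at 4500 nM, within 1500 nM to 13500 nM.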

Compound 3, half-maximal inhibitory concentration: 4630 nM
Compound 3: the middle estimate sits 1.0-fold (0.01 log units) below what was measured; measured number inside the range.
By their numbers in this assay, from the lowest: compounds 1 and 3 (each within the scatter of the next); then compound 2.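

At this aromatic carbon, opposite the ring nitrogen, 4-hydroxyphenyl in place of naphthalen-1-yl gives a 3.2-fold lower number from compound 2 to compound 3 (0.51 log units; beyond the scatter) in this assay. Compound 2 therefore now stands apart from two different groups with a single six-membered ring, where earlier only pyridin-3-yl had been set against it. Those two groups cannot be told apart here, with a 1.2-fold higher number from compound 1 to compound 3 (0.08 log units; within the scatter) in the same assay, even though one has its nitrogen in the ring and the other carries a hydroxyl.

From the compounds shown here alone, whether an unsubstituted phenyl, an aminophenyl or a carboxyphenyl at this carbon would group with compound 1 and compound 3 or with compound 2 remains open. No measurement at hand accounts for these differences.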